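The source may report more compounds than this note shows. Statements on the series, on what has been measured and on what is new or still open speak of the compounds shown alone.

Of the compounds shown here, two have been measured so far in a functional assay on PC-3 cells (Homo sapiens) for cytotoxicity, read by MTT assay, with a stated time of 72 h; on this read-out higher numbers stand for weaker inhibition and lower numbers for stronger inhibition. Compound 1 `CC1=C(/C=C/C(=O)/C=C/c2ccc(C(F)(F)F)cc2)C(C)(C)CCC1O` gives 10200 nM in this assay. Compound 2 `CC1=C(/C=C/C(=O)/C=C/c2cccc(C)c2)C(C)(C)CCC1O` gives 6200 nM in this assay. Of the two numbers, that of compound 2 is the lower, but the gap to compound 1 falls within the scatter of repeated measurements, so the two compounds are not distinguished on the data at hand.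

Compound 3 `CCOC(OCC)c1cccc(/C=C/C(=O)/C=C/C2=C(C)C(O)CCC2(C)C)c1` is not yet measured. It differs from compound 2 in one place: diethoxymethyl in place of methyl on an aromatic carbon. Going by the values given here, no measured pair shows the effect of such a change, so nothing beyond the scatter can be expected in either direction. The step from compound 2 to compound 3 is estimated as a 1.3-fold higher number from compound 2 to compound 3 (0.11 log units; within the scatter) in this assay. For compound 3 the expected value in this assay is 8000 nM, with a range from 3000 nM to 25000 nM.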

Compound 3, half-maximal inhibitory concentration: 4700 nM
For compound 3 the middle estimate is 1.7-fold (0.23 log units) above the measured one; low and high end bracket the measured number.
By their numbers in this assay, from the lowest: compounds 3, 2 and 1 (each within the scatter of the next, the first and the last beyond it).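

At this aromatic carbon, meta to a large group, the series now has its first readable one-place change: diethoxymethyl in place of methyl gives a 1.3-fold lower number from compound 2 to compound 3 (0.12 log units; within the scatter) in this assay. The entering group has 7 heavy atoms and 2 hydrogen-bond acceptors against 1 heavy atom and no acceptor for methyl, yet this single pair separates the two compounds by no more than the scatter. No measurement at hand bears on what lies behind this step.

On these data alone, it remains open how a smaller or differently built group at this carbon would read, such as an aldehyde, a carboxylic acid, an aminomethyl group or a longer alkyl chain. Also open, as far as these compounds go, is whether diethoxymethyl would give a similar step on another carbon of the same ring.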